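The source may report more compounds than this note shows. Statements on the series, on what has been measured and on what is new or still open speak of the compounds shown alone.

Compound 1 `CN(C)c1cc2[nH]c(C3CCCCC3)nc2cc1NC(=O)c1cccs1`: in an ADME assay on Vero cells (Chlorocebus sabaeus) for cytotoxicity, read by resazurin assay, with a stated time of 3 days (a higher number here means a weaker inhibitor, a lower number a stronger inhibitor), compound 1 gives > 100 ug/mL, which is a limit of the assay and not a number.
Compound 2 `CCN(CC)c1cc2[nH]c(C3CCCCC3)nc2cc1NC(=O)NCc1ccccc1`: in this assay compound 2 gives > 100 ug/mL, again a limit.
Compound 3 `COCCOC(=O)Nc1cc2nc(C3CCCCC3)[nH]c2cc1N1CCCC1`: in this assay compound 3 gives > 100 ug/mL, also a limit.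

Compound 3 therefore stands at the limit of > 100 ug/mL in this assay, at which 3 of the 3 values shown sit; with only limits shown, no order among the three compounds can be drawn. Compound 4 `O=C(Nc1cc2nc(C3CCCCC3)[nH]c2cc1N1CCCC1)OCC(F)(F)F` differs from compound 3 by trifluoromethyl in place of methoxymethyl on a saturated chain carbon bound to an oxygen next to a carbonyl group. Going by the values given here, no measured step between compounds is available for comparison, so in this assay no shift beyond the usual scatter is expected. The step that the limit leaves unreadable from compound 3 to compound 4 is expected to be small. Compound 4 is expected at about 150 ug/mL, within 60 ug/mL to 400 ug/mL, and most likely to be reported again as a limit.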

Compound 4, half-maximal inhibitory concentration: > 100 ug/mL
Compound 4 ended at the assay's limit (the forecaster's own chance of this, stated with the estimate: 80%); the middle value lies beyond the limit too.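

Compound 3 and compound 4 both give limits of the assay and not numbers, so no step can be read between them. The compounds shown leave open any order among them in this assay: the limit of > 100 ug/mL in this assay, at which 4 of the 4 values shown sit.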